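The source may report more compounds than this note shows. Statements on the series, on what has been measured and on what is new or still open speak of the compounds shown alone.

Series notes. In an assay on CHO cells for displacement of a labelled ligand from prostaglandin D2 receptor 2 (Homo sapiens), read by scintillation counting (a higher number here means a weaker inhibitor, a lower number a stronger inhibitor), compound 1 `CC(C)S(=O)(=O)c1ccc(Cl)c(C#Cc2cc(Cl)ccc2OCC(=O)O)c1` gives 2.9 nM, compound 3 `CCCS(=O)(=O)c1cccc(C#Cc2cc(C#N)ccc2OCC(=O)O)c1` gives 21 nM, and compound 2 `COCc1ccc(F)c(C#Cc2cc(Cl)ccc2OCC(=O)O)c1` gives 72 nM, the highest of the three numbers; the gap from compound 2 to compound 3 and the larger gap to compound 1 both lie beyond the scatter. Compound 4 `CS(=O)(=O)c1ccc(F)c(C#Cc2cc(Cl)ccc2OCC(=O)O)c1` has not yet been run in this assay. Relative to compound 2 the change is methylsulfonyl in place of methoxymethyl on an aromatic carbon. Within the data shown here, no single-point step between measured compounds is available, so the expectation rests on the two sulfonyl-bearing members, compound 1 at 2.9 nM and compound 3 at 21 nM, which hold the lower numbers. A drop beyond the scatter is therefore expected, estimated as a 4.8-fold lower number from compound 2 to compound 4 (0.68 log units; beyond the scatter). Compound 4 is estimated near 15 nM, within 5 nM to 50 nM.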

Compound 4, inhibition constant: 3.3 nM
Beside the measured number, compound 4's estimate is 4.5-fold (0.66 log units) above it, outside the stated range (below it).
By their numbers in this assay, from the lowest: compounds 1 and 4 (each within the scatter of the next); then compound 3; then compound 2.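

Among these compounds, this is the first single-change step: methylsulfonyl in place of methoxymethyl on an aromatic carbon gives a 22-fold lower number from compound 2 to compound 4 (1.34 log units; beyond the scatter) with the fluoro group and the rest of the core unchanged. The earlier compounds shown here, which differ in more than one place, could not isolate this position, and it now proves highly responsive to this swap. Nothing available explains the size of the step. As far as these compounds go, how an aminosulfonyl or acetyl group would read at this position stays open, as does whether the same swap carries over to a core bearing the nitrile of compound 3.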